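A few compounds are considered here, and "the series" means these few. Any claim that something is new, unique, unknown or untested is made for them only; others in the source may bear on it.

So far, two compounds with the same core have been measured in a functional assay on HT cells (Homo sapiens) for antiproliferative activity, read by fluorescence, with a stated time of 72 h; on this read-out higher numbers stand for weaker inhibition of growth and lower numbers for stronger inhibition of growth. Compound 1 `CC(C)c1n[nH]c2c(NCc3ccc(-c4ccccn4)cc3)nc(SCCO)nc12` gives 48 nM, while compound 2 `CC(C)c1n[nH]c2c(NCc3ccc(-c4ccccn4)cc3)nc(SCCC(N)=O)nc12` gives 120 nM, the higher of the two numbers and so the weaker inhibition of growth. Among the compounds with values here, the one measured step, a 2.5-fold higher number from compound 1 to compound 2 (0.40 log units; beyond the scatter), places carbamoyl in place of hydroxy on a saturated chain carbon, and it is modest but beyond the usual scatter.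

Compound 3 `CC(C)c1n[nH]c2c(NCc3ccc(-c4ccccn4)cc3)nc(S)nc12` goes further, with the difference (hydrogen in place of 2-carbamoylethyl on a sulfur). This puts hydrogen in place of 2-carbamoylethyl on a sulfur, so the whole chain is lost and only a sulfanyl remains. Within the data shown here, the measured step changed just the end of the chain, so it offers only a loose guide to size, and no measured compound shows the effect of removing the chain. Its modest size and direction suggest a similar, modest rise in this assay, though with wide uncertainty. The expected change is a 2.5-fold higher number from compound 2 to compound 3 (0.40 log units; beyond the scatter). For compound 3, the estimated value is 300 nM, with an expected range from 60 nM to 1500 nM.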

Compound 3, concentration for 50% growth inhibition: 2760 nM
Estimate against measurement, compound 3: 9.2-fold (0.96 log units) below; measured number above the stated range.
By their numbers in this assay, from the lowest: compound 1; then compound 2; then compound 3.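

In this assay taking the whole 2-carbamoylethyl chain off the sulfur gives a 23-fold higher number from compound 2 to compound 3 (1.36 log units; beyond the scatter) and taking off the 2-hydroxyethyl chain gives a 58-fold higher number from compound 1 to compound 3 (1.76 log units; beyond the scatter), so the loss of the chain weakens growth inhibition strongly whichever of the two chains is removed. Both of these steps are large, whereas changing only the end of the chain gave the modest 2.5-fold higher number from compound 1 to compound 2 (0.40 log units; beyond the scatter) and, among these three compounds, having a chain on this sulfur therefore counts for far more than whether it ends in hydroxy or carbamoyl. Nothing available explains why the bare sulfanyl compound is so much weaker.

The compounds shown leave open how much of a chain is needed, since a single methyl on the sulfur or a longer chain ending in hydroxy could fall anywhere between or beyond these numbers. They also leave open whether a chain ending in an amine or a carboxylic acid would keep the stronger growth inhibition of compound 1 or lose part of it.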